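Efficacy notes: pyridyl for phenyl on the cyclopropyl series

The compounds below may be only part of what the source reports. "The series", "measured", "known", "first", "only" and "open" are said of these compounds alone.

Measured compounds, an assay on isolated protein for agonist activity at Bile acid receptor (Homo sapiens), read by FRET; on this read-out lower numbers stand for smaller maximal responses and higher numbers for larger maximal responses:
- compound 1, `CCO[C@]1(c2ccc(OCc3c(-c4c(Cl)cccc4Cl)noc3C3CC3)cc2Cl)C[C@H](c2cccc(C(=O)O)c2)C1`: 94%
- compound 2, `O=C(O)c1cncc(N2CC(O)(c3ccc(OCc4c(-c5c(Cl)cccc5Cl)noc4C4CC4)cc3Cl)C2)c1`: 102%
- compound 3, `O=C(O)c1cccc([C@H]2C[C@@H]2c2ccc(OCc3c(-c4c(Cl)cccc4Cl)noc3C3CC3)cc2Cl)c1`: 101%

In this assay compound 3 gives 101%. The three values lie within the scatter of one another: the gap from compound 3 to compound 2 is a single percentage point, and the gap to compound 1 is seven points, both inside the usual spread of repeated runs. Nothing in the set separates one compound from another.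

Compound 4, `O=C(O)c1cncc(C2CC2c2ccc(OCc3c(-c4c(Cl)cccc4Cl)noc3C3CC3)cc2Cl)c1`, has not yet been run in this assay. It differs from compound 3 in one place: 2-(5-carboxypyridin-3-yl)cyclopropyl in place of 2-(3-carboxyphenyl)cyclopropyl on an aromatic carbon

Among the compounds with values here, no pair of measured compounds differs in exactly this way, so no measured step can be carried over. What the set does show is that compound 2, which carries a 5-carboxypyridin-3-yl group in its own setting, reaches a maximal response indistinguishable from the carboxyphenyl compounds 1 and 3. The expectation is therefore that the step of a number 3 percentage points lower from compound 3 to compound 4 (within the scatter) stays within the scatter, in no particular direction. Compound 4 is estimated to give about 98%, with a likely range from 85% to 110%.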

Compound 4, largest response reached (reported as efficacy), in percent of the reference or control that the assay uses: 103%
Estimate against measurement, compound 4: 5 percentage points below, within the range that was stated.
By their numbers in this assay, from the lowest: compounds 1, 3, 2 and 4 (each within the scatter of the next).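

Exchanging 2-(3-carboxyphenyl)cyclopropyl for 2-(5-carboxypyridin-3-yl)cyclopropyl on this aromatic carbon, ortho to a chloro group, gives a number 2 percentage points higher from compound 3 to compound 4 (within the scatter) in this assay and so leaves the maximal response unchanged within the scatter. Within the data shown here, this matched pair is the only direct reading of the change in the set, and it shows that the six-membered aromatic ring with 1 hetero atom is tolerated at this position, which the earlier compounds could suggest only from a different setting in compound 2. Nothing available bears on why the response holds across this change.

From the compounds shown here alone, compound 3 has 2 defined stereocentres, whereas none are defined in this group in compound 4, so any difference between individual stereoisomers of compound 4 stays open. Also open, going by these compounds, is whether the response holds when a primary amide or a tetrazole takes the place of the carboxylic acid on the pyridine ring.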